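Triazole substituent swap on the shared core

The source may hold more compounds than are shown below. What is called first, only, known or untested is meant among the compounds shown, and "the series" means these compounds.

Compound 1 `O=C1O[C@H]([C@@H](O)Cn2cc(-c3cccc(O)c3)nn2)C(OCc2ccccc2)=C1OCc1ccccc1` gives 39300 nM in a functional assay on HeLa cells (Homo sapiens) for antiproliferative activity, read by MTT assay, with a stated time of 72 h; on this read-out higher numbers stand for weaker inhibition and lower numbers for stronger inhibition.
Compound 2 `CCCCCCCCCCc1cn(C[C@H](O)[C@H]2OC(=O)C(OCc3ccccc3)=C2OCc2ccccc2)nn1` gives 22900 nM in this assay.

Compound 2 holds the lower of the two numbers, yet the step of a 1.7-fold lower number from compound 1 to compound 2 (0.23 log units; within the scatter) lies within the scatter, so the two compounds cannot be separated. Compound 3 `Cc1ccc(-c2cn(C[C@H](O)[C@H]3OC(=O)C(OCc4ccccc4)=C3OCc3ccccc3)nn2)cc1` differs from compound 2 by 4-methylphenyl in place of decyl on an aromatic carbon. Among the compounds with values here, the only step that bears on this change is a 1.7-fold lower number from compound 1 to compound 2 (0.23 log units; within the scatter), a ring-to-chain exchange at the same place, and it stayed within the scatter. Returning to an aromatic ring is expected to give at most a step of that kind, a 1.3-fold higher number from compound 2 to compound 3 (0.12 log units; within the scatter). Compound 3 is therefore estimated at 30000 nM, within a range from 10000 nM to 90000 nM.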

Compound 3, half-maximal inhibitory concentration: 25500 nM
Compound 3: the middle estimate sits 1.2-fold (0.07 log units) above what was measured; measured number inside the range.
By their numbers in this assay, from the lowest: compounds 2, 3 and 1 (each within the scatter of the next).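

In this assay, 4-methylphenyl on this aromatic carbon cannot be separated from decyl (a 1.1-fold higher number from compound 2 to compound 3 (0.05 log units; within the scatter)) or from 3-hydroxyphenyl (a 1.5-fold lower number from compound 1 to compound 3 (0.19 log units; within the scatter)). The position has now carried a chain and two differently substituted phenyl rings, with no step beyond the scatter. No supporting data bear on why these groups read alike.

On these data alone, whether an amine or a carboxylic acid on the phenyl ring, or a chain shorter than decyl, would move the number beyond the scatter remains open. As far as these compounds go, the effect of replacing either benzyl group on the shared core is also open.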